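A few compounds are considered here, and "the series" means these few. Any claim that something is new, unique, unknown or untested is made for them only; others in the source may bear on it.

Three compounds share one core. Compound 1 `CCCCC(N)c1cc(C(F)(F)F)ccc1N1CCN(C(=O)CCc2ccc(Cl)cc2Cl)CC1` gives 190 nM in an assay on HEK293 cells for displacement of a labelled ligand from Melanocortin receptor 4 (Homo sapiens); a lower number here means a stronger inhibitor, a higher number a weaker inhibitor. Compound 2 `CCN[C@H](c1cc(C(F)(F)F)ccc1N1CCN(C(=O)CCc2ccc(Cl)cc2Cl)CC1)C(C)CC` gives 92 nM in this assay, and compound 3 `CCC(C)[C@H](NC[C@H]1CCCN1)c1cc(C(F)(F)F)ccc1N1CCN(C(=O)CCc2ccc(Cl)cc2Cl)CC1` gives 110 nM. Compound 3 thus holds the second highest of the three numbers, with a 1.2-fold higher number from compound 2 to compound 3 (0.08 log units; within the scatter) and a 1.7-fold lower number from compound 1 to compound 3 (0.24 log units; within the scatter) both small. Compound 4 `COCCN[C@@H](CC(C)C)c1cc(C(F)(F)F)ccc1N1CCN(C(=O)CCc2ccc(Cl)cc2Cl)CC1` differs from compound 3 by 1-((2-methoxyethyl)amino)-3-methylbutyl in place of 2-methyl-1-(((pyrrolidin-2-yl)methyl)amino)butyl on an aromatic carbon. Among the compounds with values here, the steps that bear on this change are a 2.1-fold lower number from compound 1 to compound 2 (0.31 log units; beyond the scatter), a modest gain on altering the amine substituent, and a 1.2-fold higher number from compound 2 to compound 3 (0.08 log units; within the scatter), which shows that pyrrolidin-2-yl in place of methyl on that chain carbon made no difference beyond the scatter. A further change of this kind is therefore expected to move the number little, a 1.1-fold lower number from compound 3 to compound 4 (0.04 log units; within the scatter). Compound 4 is estimated at 100 nM, in a range from 40 nM to 260 nM.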

Compound 4, inhibition constant: 620 nM
Beside the measured number, compound 4's estimate is 6.2-fold (0.79 log units) below it, outside the stated range (above it).
By their numbers in this assay, from the lowest: compounds 2, 3 and 1 (each within the scatter of the next, the first and the last beyond it); then compound 4.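

Earlier changes at this position moved the number little, but in this assay the 1-((2-methoxyethyl)amino)-3-methylbutyl group gives a 5.6-fold higher number from compound 3 to compound 4 (0.75 log units; beyond the scatter), a 6.7-fold higher number from compound 2 to compound 4 (0.83 log units; beyond the scatter) and a 3.3-fold higher number from compound 1 to compound 4 (0.51 log units; beyond the scatter), so the position is not indifferent to what it carries. Compound 4 is the weakest of the four, but against compound 2 and compound 3 it alters both the carbon chain and the amine substituent, so the two changes cannot be separated. Nothing measured here explains this loss.

Going by these compounds, it remains open whether the 2-methoxyethyl amine would fare better on the 2-methylbutyl chain. A 2-hydroxyethyl amine or a carboxylic acid at the end of that substituent is also untested among the compounds shown.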